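This account rests on a few compounds, and the source may have more. Where it says the series, first, only, none or still open, it means among the compounds named here.

Three analogues of the shared core carry different aryl groups on the aromatic nitrogen: compound 1 `COc1ccc(-n2nncc2CN2C(=O)C3(C(C#N)=C(N)Oc4c(N)cc5nc6ccccc6nc5c43)c3ccccc32)cc1`, compound 2 `CCOc1ccccc1-n1nncc1CN1C(=O)C2(C(C#N)=C(N)Oc3c(N)cc4nc5ccccc5nc4c32)c2ccccc21` and compound 3 `N#CC1=C(N)Oc2c(N)cc3nc4ccccc4nc3c2C12C(=O)N(Cc1cnnn1-c1c(F)cccc1F)c1ccccc12`. In a functional assay on HCT-116 cells (Homo sapiens) for antiproliferative activity, read by MTT assay, with a stated time of 48 h (on this read-out higher numbers stand for weaker inhibition and lower numbers for stronger inhibition), compound 1 returns only a limit, > 50000 nM. In this assay compound 2 likewise returns a limit, > 50000 nM. In this assay compound 3 also gives a limit, > 50000 nM. Compound 3 thus stands at the limit, together with every other value shown (the limit of > 50000 nM in this assay, at which 3 of the 3 values shown sit). The steps a step that the two limits leave unreadable from compound 1 to compound 2, a step that the two limits leave unreadable from compound 1 to compound 3 and a step that the two limits leave unreadable from compound 2 to compound 3 are accordingly of unreadable size. Compound 4 `COc1ccc(OC)c(-n2nncc2CN2C(=O)C3(C(C#N)=C(N)Oc4c(N)cc5nc6ccccc6nc5c43)c3ccccc32)c1` differs from compound 3 by 2,5-dimethoxyphenyl in place of 2,6-difluorophenyl on an aromatic nitrogen. No measured aryl exchange gives a readable size, so no step beyond the scatter in this assay is expected. The expected step is a step that the limit leaves unreadable from compound 3 to compound 4. Compound 4 is expected to sit at the limit as well, estimated near 60000 nM within 20000 nM to 200000 nM.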

Compound 4, half-maximal inhibitory concentration: > 50000 nM
Compound 4 was reported as a limit (the forecaster's own chance of this, stated with the estimate: 85%); the middle value lies beyond the limit too.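

The steps between compound 4 and compound 1, compound 2 and compound 3 cannot be read, because all four values are limits: the limit of > 50000 nM in this assay, at which 4 of the 4 values shown sit. The compounds shown leave open whether in this assay any aryl group on the aromatic nitrogen gives a value short of the limit.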